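Working notes: aryl exchange from compound 3 to compound 4

A few compounds are considered here, and "the series" means these few. Any claim that something is new, unique, unknown or untested is made for them only; others in the source may bear on it.

Values so far in a functional assay on PC-3 cells (Homo sapiens) for antiproliferative activity, read by MTT assay, with a stated time of 72 h; a higher number here means a weaker inhibitor, a lower number a stronger inhibitor
- compound 1 `O=C(N/N=C/c1ccccc1)Nc1ccc(Oc2ccnc3[nH]ccc23)c(F)c1` gives 7940 nM
- compound 2 `O=C(N/N=C/c1ccc(F)cc1)Nc1ccc(Oc2ccnc3[nH]ccc23)c(F)c1` gives 2330 nM
- compound 3 `O=C(N/N=C/c1cccc([N+](=O)[O-])c1)Nc1ccc(Oc2ccnc3[nH]ccc23)c(F)c1` gives 5140 nM

Compound 3 stays close to one neighbour (a 1.5-fold lower number from compound 1 to compound 3 (0.19 log units; within the scatter)) but apart from the other (a 2.2-fold higher number from compound 2 to compound 3 (0.34 log units; beyond the scatter)) in this assay.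

The next change leads to compound 4 `O=C(N/N=C/c1ccc(F)cc1Cl)Nc1ccc(Oc2ccnc3[nH]ccc23)c(F)c1` and is counted as follows (2-chloro-4-fluorophenyl in place of 3-nitrophenyl on a carbon with a double bond to nitrogen), with 2-chloro-4-fluorophenyl in place of 3-nitrophenyl on a carbon with a double bond to nitrogen.

Going by the values given here, two measured steps bear on this change. Adding the fluoro group gave a modest step (a 3.4-fold lower number from compound 1 to compound 2 (0.53 log units; beyond the scatter)), whereas adding the nitro group gave none beyond the scatter. Compound 4 keeps the fluoro group of compound 2 and loses the nitro group, so the modest step between the 4-fluorophenyl and 3-nitrophenyl compounds (a 2.2-fold higher number from compound 2 to compound 3 (0.34 log units; beyond the scatter)) is the closest guide, read in reverse. Among the compounds with values here, no measured compound carries a chloro group, so that part of the change has no guide and the range stays wide.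

A modest step towards a lower number is therefore expected (a 2.1-fold lower number from compound 3 to compound 4 (0.31 log units; beyond the scatter)). Compound 4 is estimated at 2500 nM (expected range 900 nM to 6000 nM).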

Compound 4, half-maximal inhibitory concentration: 3 nM
Estimate against measurement, compound 4: 830-fold (2.92 log units) above; the measured number lies below the stated range.
By their numbers in this assay, from the lowest: compound 4; then compound 2; then compounds 3 and 1 (each within the scatter of the next).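

In this assay, going by these compounds alone, the aryl group on the carbon with a double bond to nitrogen can move the number far more than the earlier compounds showed: their steps were modest at most, whereas adding a chloro group to the 4-fluorophenyl group gives a 780-fold lower number from compound 2 to compound 4 (2.89 log units; beyond the scatter). The full exchanges point the same way, with 2-chloro-4-fluorophenyl in place of 3-nitrophenyl giving a 1700-fold lower number from compound 3 to compound 4 (3.23 log units; beyond the scatter) and the same group in place of phenyl giving a 2600-fold lower number from compound 1 to compound 4 (3.42 log units; beyond the scatter), so the fluoro group alone reaches only a small part of what the chloro and fluoro groups reach together. Nothing available here accounts for the size of this step.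

These compounds leave open whether the chloro group needs the fluoro group, since a phenyl group carrying chloro alone is not among those shown. Going by these compounds, it also remains open whether bromo, methyl or methoxy in place of the chloro group would keep a number of this order, or whether the large step belongs to chloro alone.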